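The source may hold more compounds than are shown below. What is called first, only, known or untested is meant among the compounds shown, and "the series" means these compounds.

Compound 1, `Nc1cccc(-c2cc3ccccc3[nH]2)c1`: in an assay on isolated protein for inhibition of Aromatase (Homo sapiens), read by fluorescence, using NADPH, with a stated time of 30 min, tested at 50 uM (a lower number here means less inhibition, a higher number more inhibition at the concentration tested (going by the name of the read-out)), compound 1 gives 26.7%.
Compound 2, `Clc1cccc(-c2cc3ccccc3[nH]2)c1`: in this assay compound 2 gives 24.2%.

Among the measured compounds shown here, compound 2 stands level with compound 1 on the numbers in hand: the single measured step, a number 2.5 percentage points lower from compound 1 to compound 2 (within the scatter), lies within the scatter, so the two cannot be told apart. Compound 3, `COc1cccc(-c2cc3ccccc3[nH]2)c1`, is reached from compound 2 by the change (methoxy in place of chloro on an aromatic carbon). For the measured compounds named here, the only measured step that bears on it is the replacement at the same position, and that step was too small to register. Nothing in the two measured compounds suggests that the group at this position moves this assay beyond the scatter. The account therefore expects a step of about a number 0.8 percentage points higher from compound 2 to compound 3 (within the scatter) from compound 2 to compound 3, that is, no change beyond the scatter. For compound 3 the expected value is 25%, with a range from 10% to 40%.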

Compound 3, a percentage reported as inhibition, at one concentration (the size of the read-out at that concentration, not a potency): 48.4%
Compound 3: the middle estimate sits 23.4 percentage points below what was measured; the measured number lies above the stated range.
By their numbers in this assay, from the lowest: compounds 2 and 1 (each within the scatter of the next); then compound 3.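

Methoxy in place of chloro gives a number 24.2 percentage points higher from compound 2 to compound 3 (beyond the scatter) and methoxy in place of amino gives a number 21.7 percentage points higher from compound 1 to compound 3 (beyond the scatter) in this assay and so shows that this position, on an aromatic carbon of a six-membered aromatic ring of carbon only, does answer to the group it carries, which the level pair of amino and chloro could not show. Of the three groups shown, methoxy alone stands apart, while amino and chloro remain within the scatter of each other. Nothing at hand explains why methoxy stands apart.

The compounds shown do not tell whether the oxygen or the carbon of methoxy goes with the higher number, which a hydroxyl group could help to settle. On these data alone, whether a longer chain such as ethoxy keeps, extends or loses the step also stays open.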